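The compounds below may be only part of what the source reports. "The series", "measured", "known", "first", "only" and "open" are said of these compounds alone.

Compound 1 `O=c1c(CSC(=S)N2CCCC2)coc2ccccc12` and compound 2 `Cc1ccc2c(=O)c(CSC(=S)N3CCCC3)coc2c1` share one core and differ only by a methyl group on an aromatic carbon. Among the compounds with values here, in a functional assay on LM7 cells (Homo sapiens) for antiproliferative activity, read by MTT assay, with a stated time of 72 h (a higher number here means a weaker inhibitor, a lower number a stronger inhibitor), compound 1 gives 6000 nM, the highest of the two numbers known, and compound 2 gives 3400 nM, a change of a 1.8-fold lower number from compound 1 to compound 2 (0.25 log units; within the scatter). Compound 3 `O=c1c(CSC(=S)N2CCOCC2)coc2ccccc12` carries morpholin-4-yl in place of pyrrolidin-1-yl on a thiocarbonyl carbon. Within the data shown here, no measured step touches this part of the molecule, and the single known step stays within the scatter, so nothing beyond the scatter is expected here. For compound 3 in this assay the estimate is 6000 nM, between 2500 nM and 15000 nM. That estimate means an expected step of no change at the digits printed from compound 1 to compound 3 (within the scatter).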

Compound 3, half-maximal inhibitory concentration: 12000 nM
Estimate against measurement, compound 3: 2.0-fold (0.30 log units) below, and the stated range covers the measured number.
By their numbers in this assay, from the lowest: compounds 2, 1 and 3 (each within the scatter of the next, the first and the last beyond it).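

Within the data shown here, the thiocarbonyl carbon is now probed for the first time: in this assay, morpholin-4-yl in place of pyrrolidin-1-yl gives a 2.0-fold higher number from compound 1 to compound 3 (0.30 log units; within the scatter) on this carbon. Exchanging the five-membered ring for a six-membered one that adds an oxygen and a hydrogen-bond acceptor therefore leaves the number within the scatter. No measurement at hand offers an explanation for this reading.

Still open, on these data alone, is how piperazin-1-yl, with a second ring nitrogen, or an open-chain group such as dimethylamino would read on this carbon.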